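A few compounds are considered here, and "the series" means these few. Any claim that something is new, unique, unknown or untested is made for them only; others in the source may bear on it.

Compound 1 `Cc1cn(C2CC(N=[N+]=[N-])C(COC(=O)NCCCC(=O)OC(C)(C)C)O2)c(=O)[nH]c1=O`, compound 2 `Cc1cn(C2CC(N=[N+]=[N-])C(COC(=O)NCCCN)O2)c(=O)[nH]c1=O` and compound 3 `Cc1cn(C2CC(N=[N+]=[N-])C(COC(=O)CCCC(=O)OC(C)(C)C)O2)c(=O)[nH]c1=O` were run in an ADME assay on the whole organism (serum) with Homo sapiens as the target; a lower number here means that the compound disappears faster, a higher number that the compound lasts longer. Compound 1 reaches the limit of this assay at > 48 h, not a number. Compound 2 likewise sits at the limit, > 48 h. Compound 3 gives 0.55 h. The change amino in place of tert-butoxycarbonyl on a saturated chain carbon, three bonds along the chain from an amide-type nitrogen gives a step that the two limits leave unreadable from compound 1 to compound 2, both values lying at the limit of > 48 h in this assay, at which 2 of the 3 values shown sit. Then an at least 87-fold lower number from compound 2 to compound 3 (1.94 log units; beyond the scatter). The difference between the cores of compound 1 and compound 3 is not broken down here. Compound 4 `Cc1cn(C2CC(N=[N+]=[N-])C(COC(=O)CCCN)O2)c(=O)[nH]c1=O` follows from compound 3 by amino in place of tert-butoxycarbonyl on a saturated chain carbon, three bonds along the chain from a carbonyl carbon, the same kind of change, the place now three bonds along the chain from a carbonyl carbon rather than from an amide-type nitrogen. Since the earlier step is unreadable, the expected step of a 1.8-fold higher number from compound 3 to compound 4 (0.26 log units; within the scatter) rests only on compound 3 at 0.55 h. Compound 4 is estimated at 1 h, between 0.25 h and 6 h.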

Compound 4, half-life in the Homo sapiens assay: 0.433 h
For compound 4 the middle estimate is 2.3-fold (0.36 log units) above the measured one, and the stated range covers the measured number.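

In the Homo sapiens assay, amino in place of tert-butoxycarbonyl on the core of compound 3 gives a 1.3-fold lower number from compound 3 to compound 4 (0.10 log units; within the scatter), whereas in a physicochemical assay for lipophilicity (on this read-out lower numbers stand for lower lipophilicity and higher numbers for higher lipophilicity), compound 3 gives 1.17 and compound 4 gives -0.9, and the same change gives a number 2.07 log units lower from compound 3 to compound 4 (beyond the scatter). The same change on the core of compound 1 cannot be read, as compound 1 and compound 2 both stand at a limit, not a number: the limit of > 48 h in the Homo sapiens assay, at which 2 of the 4 values shown sit. In the Homo sapiens assay, 3-aminopropyl in place of (3-aminopropyl)amino on a carbonyl carbon gives an at least 110-fold lower number from compound 2 to compound 4 (2.04 log units; beyond the scatter), a size that rests on a limit, so the series neither confirms nor refutes that the amino change carries from one core to the other.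

Still open, as far as these compounds go, is how a carboxylic acid in place of tert-butoxycarbonyl would read on either core in the Homo sapiens assay. Also open, from the compounds shown here alone, is whether a longer chain ending in amino would read as compound 4 does.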